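The source may hold more compounds than are shown below. What is called first, only, known or untested is meant among the compounds shown, and "the series" means these compounds.

Compound 1 `COc1ccc(-n2c(Nc3nc(-c4ccc([N+](=O)[O-])cc4)cs3)n[nH]c2=S)cc1` gives 100 mg/kg in a functional assay on the whole organism (strain Swiss albino) for inhibition, with Mus musculus as the target, with a stated time of 0.5 h; on this read-out higher numbers stand for an effect only at larger amounts of compound and lower numbers for an effect already at smaller amounts.
Compound 2 `COc1ccccc1-n1c(Nc2nc(-c3ccc([N+](=O)[O-])cc3)cs2)n[nH]c1=S` gives 100 mg/kg in this assay.

Compound 2 thus stands level with compound 1 at the digits shown; the single measured step, no change at the digits printed from compound 1 to compound 2 (within the scatter), moved nothing beyond the scatter. Compound 3 `COc1ccccc1-n1c(Nc2nc(-c3ccccc3)cs2)n[nH]c1=S` differs from compound 2 by hydrogen in place of nitro on an aromatic carbon. Going by the values given here, no measured step touches the nitro group, so the one known step gives no guidance for this change, and nothing in the numbers points in either direction. The expected step is therefore no change at the digits printed from compound 2 to compound 3 (within the scatter), meaning no change beyond the scatter. Compound 3 is estimated to give 100 mg/kg, with a range from 50 mg/kg to 200 mg/kg.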

Compound 3, minimum effective dose: 100 mg/kg
Beside the measured number, compound 3's estimate shows no gap at the digits printed; measured number inside the range.
By their numbers in this assay, from the lowest: compounds 1, 2 and 3 (each within the scatter of the next).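

Going from 4-nitrophenyl to phenyl gives no change at the digits printed from compound 2 to compound 3 (within the scatter) in this assay. The nitro group can therefore be dropped from this position without moving the minimum effective dose beyond the scatter, a change on the other aryl group that the earlier step between compound 1 and compound 2 did not cover. No evidence is available on the reason for this result.

On these data alone, whether an amine or a carboxylic acid at this place would give the same reading stays open. So does whether any change to the shared core can lower the dose needed.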